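This account rests on a few compounds, and the source may have more. Where it says the series, first, only, none or still open, it means among the compounds named here.

Measured in an ADME assay on HEK293 cells (Homo sapiens) for cytotoxicity, read by CellTiter-Glo and resazurin assay, with a stated time of 72 h; on this read-out lower numbers stand for an effect already at smaller amounts and higher numbers for an effect only at larger amounts of compound:
Compound 1 `COc1cc(F)cc(-c2ccc(C(=O)N(Cc3cccc(OCCCCCC(=O)O)c3)C(C)C)cc2)c1` gives > 26000 nM, which is a limit of the assay and not a number.
Compound 2 `COc1ccc(F)c(-c2ccc(C(=O)N(Cc3cccc(OCCCCCC(=O)O)c3)C(C)C)cc2)c1` gives > 26000 nM, again a limit of the assay.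
Compound 3 `CCOC(=O)CCCCCOc1cccc(CN(C(=O)c2ccc(-c3cc(F)cc(OC)c3)cc2)C(C)C)c1` gives > 26000 nM, again a limit of the assay.

Compound 1 and compound 2 differ in one place: 2-fluoro-5-methoxyphenyl in place of 3-fluoro-5-methoxyphenyl on an aromatic carbon. The step that the two limits leave unreadable from compound 1 to compound 2. The core of compound 3 differs from the core of compound 1 by ethyl in place of hydrogen on an oxygen next to a carbonyl group, and the step that the two limits leave unreadable from compound 1 to compound 3.

Compound 4 `CCOC(=O)CCCCCOc1cccc(CN(C(=O)c2ccc(-c3cc(OC)ccc3F)cc2)C(C)C)c1` has not yet been measured. It differs from compound 3 by 2-fluoro-5-methoxyphenyl in place of 3-fluoro-5-methoxyphenyl on an aromatic carbon, the same change as from compound 1 to compound 2, at the same place. In this assay compound 4 is expected to show a step that the limit leaves unreadable from compound 3 to compound 4, an expectation that rests on (the limit of > 26000 nM in this assay, at which 3 of the 3 values shown sit). The estimate for compound 4 is 40000 nM, most likely reported again only as a limit.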

Compound 4, half-maximal effective concentration: > 26000 nM
Compound 4 was reported as a limit (the forecaster's own chance of this, stated with the estimate: 85%); the middle value is on the limit's open side.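

In this assay compound 4 gives > 26000 nM, again a limit of the assay and not a number. Among these compounds, no step from compound 3 or compound 2 to compound 4 can be read. The compounds shown leave open whether the fluorine's position or the ethyl group changes this effect on the cells at all.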